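The compounds below may be only part of what the source reports. "The series", "measured", "known", "first", "only" and "open" are said of these compounds alone.

Compound 1 `COc1ccc(-c2cc(/C=C/C(=O)c3ccc(N)cc3)[nH]n2)cc1` gives 100% in a functional assay on OVCAR-8 cells (Homo sapiens) for cytotoxicity, read by sulforhodamine B assay, with a stated time of 48 h, tested at 0.1 uM; a lower number here means a stronger effect, a higher number a weaker effect of the compound at the concentration tested.
Compound 2 `COc1ccc(-c2cc(/C=C/C(=O)c3ccc(N)cc3)[nH]n2)cc1OC` gives 99% in this assay.
Compound 3 `COc1cc(C(=O)/C=C/c2cc(-c3cc(OC)c(OC)c(OC)c3)n[nH]2)cc(OC)c1OC` gives 94% in this assay.

All three numbers sit close together, and none of the gaps between them goes beyond the usual scatter. Compound 2 and compound 1 differ in one place: hydrogen in place of methoxy on an aromatic carbon. The step that this made is a number 1 percentage points higher from compound 2 to compound 1 (within the scatter). How the core of compound 3 differs from the core of compound 2 is not broken down here.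

Compound 4 `COc1ccc(-c2cc(/C=C/C(=O)c3cc(OC)c(OC)c(OC)c3)[nH]n2)cc1OC` has not yet been measured in this assay. Compared with compound 3 it shows (hydrogen in place of methoxy on an aromatic carbon). Going by the values given here, this is the same kind of change as the one between compound 2 and compound 1, though not the same: here the place is also meta to a methoxy group. Because the step of a number 1 percentage points higher from compound 2 to compound 1 (within the scatter) stayed within the scatter, a similarly small step is expected here as well: a number 2 percentage points higher from compound 3 to compound 4 (within the scatter). Compound 4 is therefore estimated at 96%, most likely between 87% and 102%.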

Compound 4, a percentage reported as activity, at one concentration (the size of the read-out at that concentration, not a potency): 100%
Beside the measured number, compound 4's estimate is 4 percentage points below it; measured number inside the range.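

Putting hydrogen in place of methoxy on an aromatic carbon gives a number 6 percentage points higher from compound 3 to compound 4 (within the scatter) in this assay. Set beside the earlier case, the change carries from one core to the other with no difference that can be told apart: the same change on two cores in this assay, a number 1 percentage points higher (within the scatter) from compound 2 to compound 1 and a number 6 percentage points higher (within the scatter) from compound 3 to compound 4, 5 percentage points apart, within the scatter of two such steps This shows only that the change stays within the scatter on these two cores at a single concentration; it gives no potency and does not show that the same would hold on a compound with a clearly lower number.

The compounds shown leave open whether another group in this place, such as a hydroxyl, a chlorine or an ethoxy, would move the number beyond the scatter. They also leave open how these compounds compare at higher concentrations.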